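Extending the Methylamide to an Ethylamide on the Pyridine Side

This account rests on a few compounds, and the source may have more. Where it says the series, first, only, none or still open, it means among the compounds named here.

Measured so far:
Compound 1, `CNC(=O)c1cc(Oc2ccc(NC(=O)c3cc4cccnc4n(-c4ccccc4)c3=O)cc2)ccn1`: 250 nM
Compound 2, `CNC(=O)c1cc(Oc2ccc(NC(=O)c3cc4cccnc4n(-c4ccc(Cl)cc4)c3=O)cc2)ccn1`: 390 nM

Both compounds were tested in a functional assay on HT-29 cells (Homo sapiens) for antiproliferative activity, read by MTT assay, with a stated time of 72 h; a higher number here means a weaker inhibitor, a lower number a stronger inhibitor. Compound 1 has the lowest of the two numbers; its nearest neighbour is compound 2, and the difference a 1.6-fold higher number from compound 1 to compound 2 (0.19 log units; within the scatter) is within the scatter. Compound 3, `CCNC(=O)c1cc(Oc2ccc(NC(=O)c3cc4cccnc4n(-c4ccccc4)c3=O)cc2)ccn1`, has not yet been measured. It differs from compound 1 by methyl in place of hydrogen on a saturated chain carbon bound to an amide-type nitrogen, so the methylcarbamoyl group becomes an ethylcarbamoyl group. Among the measured compounds shown here, no measured step touches this part of the molecule; the only measured step, a 1.6-fold higher number from compound 1 to compound 2 (0.19 log units; within the scatter), concerns the aryl group on the other end of the shared core and offers no direct guide. With nothing pointing either way, no step beyond the scatter is expected, so a 1.1-fold higher number from compound 1 to compound 3 (0.05 log units; within the scatter) is the estimate. Compound 3 is therefore expected to give about 280 nM, with a likely range from 120 nM to 650 nM.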

Compound 3, half-maximal inhibitory concentration: 220 nM
Compound 3: middle estimate off by 1.3-fold (0.10 log units), on the high side, within the range that was stated.
By their numbers in this assay, from the lowest: compounds 3, 1 and 2 (each within the scatter of the next).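

Among the compounds shown here, the only earlier step, chloro in place of hydrogen on an aromatic carbon, did not touch this place, so this is the first reading of the methylcarbamoyl group. In this assay, for the compounds shown here, changing it to ethylcarbamoyl gives a 1.1-fold lower number from compound 1 to compound 3 (0.06 log units; within the scatter), so this one added methyl carbon on a saturated chain carbon bound to an amide-type nitrogen produces no step that can be told from repeat-measurement noise. No supporting measurement bears on why the two compounds read alike.

A single small step cannot show how much change this place accepts, so a longer chain such as propyl, a cyclopropyl ring or a chain ending in an amine could read alike or differently. On these data alone, it also remains open whether ethylcarbamoyl would read the same alongside the chloro group of compound 2.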